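The source may report more compounds than this note shows. Statements on the series, on what has been measured and on what is new or still open speak of the compounds shown alone.

Measured so far in an ADME assay on HepG2 cells (Homo sapiens) for cytotoxicity, read by MTT assay, with a stated time of 72 h; a lower number here means that less compound is tolerated, a higher number that more compound is tolerated:
- compound 1 `COc1ccccc1C#Cc1cc(Cl)cn2c([N+](=O)[O-])c(CS(=O)(=O)c3ccccc3)nc12`: > 3900 nM, a limit
- compound 2 `O=[N+]([O-])c1c(CS(=O)(=O)c2ccccc2)nc2c(C#Cc3cccs3)cc(Cl)cn12`: > 3900 nM, a limit
- compound 3 `O=[N+]([O-])c1c(CS(=O)(=O)c2ccccc2)nc2c(C#CCO)cc(Cl)cn12`: 10100 nM

Among the compounds with values here, compound 3, at 10100 nM, holds the only true number in this assay so far. The other two results are not numbers: the limit of > 3900 nM in this assay, at which 2 of the 3 values shown sit. Compound 3 therefore cannot be ranked against either of them.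

The next compound is compound 4 `O=[N+]([O-])c1c(CS(=O)(=O)c2ccccc2)nc2c(C#CC3(O)CCCCC3)cc(Cl)cn12`, which carries 1-hydroxycyclohexyl in place of hydroxymethyl on a triple-bonded carbon.

Three measured steps change this same place: a step that the two limits leave unreadable from compound 1 to compound 2, a step that the limit leaves unreadable from compound 1 to compound 3 and a step that the limit leaves unreadable from compound 2 to compound 3. None of them has a readable size, so the series gives no measured size or direction for a change at this carbon. The value of compound 3, 10100 nM, is the only numerical anchor, and the estimate stays close to it.

No step beyond the scatter is expected, and no direction can be assigned with confidence. The expected change is a 1.3-fold lower number from compound 3 to compound 4 (0.10 log units; within the scatter). For compound 4 the estimated value is 8000 nM, with an expected range of 3000 nM to 20000 nM. A result reported only as a limit would also be unsurprising.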

Compound 4, half-maximal cytotoxic concentration: > 25000 nM
Compound 4: no number, only a limit; the forecaster's own chance of this, stated with the estimate: 40%; middle value at least 3.1-fold (0.49 log units) away from the limit.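

At this triple-bonded carbon the series now has its first readable step in this assay: an at least 2.4-fold higher number from compound 3 to compound 4 (0.39 log units; beyond the scatter). The groups on the two sides of this step, hydroxymethyl and 1-hydroxycyclohexyl, count the same hydrogen-bond donors and acceptors, and the entering group adds one six-membered non-aromatic ring of carbon only, so a change at this carbon can pass the scatter with those counts unchanged. The step gives only a lower bound on the size, as the result for compound 4 is a limit and not a number: the limit of > 25000 nM in this assay, at which 1 of the 4 values shown sits.

Within the data shown here, the steps from compound 1 and from compound 2 to compound 4 cannot be read, and neither can the earlier steps among compound 1, compound 2 and compound 3, so the 2-methoxyphenyl and thiophen-2-yl groups stay unranked against both hydroxylated groups: the limit of > 3900 nM in this assay, at which 2 of the 4 values shown sit. It also remains open whether the step follows the ring or the hydroxyl group, a question that a plain cyclohexyl group, a 1-aminocyclohexyl group or a longer hydroxyalkyl chain at the same carbon would bear on.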